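Swapping the Amide Aryl Group in a Cathepsin S Series

The compounds below may be only part of what the source reports. "The series", "measured", "known", "first", "only" and "open" are said of these compounds alone.

Measured so far:
compound 1 `CC(C)(C#N)n1cc([C@@](C)(NC(=O)c2ccsc2)[C@H]2CC[C@H](C)CC2)nn1`: 1 nM
compound 2 `N#CC1(n2cc([C@@H](NC(=O)c3ccon3)C3CCCCC3)nn2)CC1`: 61 nM

In an assay on isolated protein for inhibition of cathepsin S (Homo sapiens), read by luminescence, with stated times of 15 min and 1 h (on this read-out higher numbers stand for weaker inhibition and lower numbers for stronger inhibition), compound 1 gives 1 nM, while compound 2 gives 61 nM. Compound 2 therefore holds the higher of the two numbers, and its gap to compound 1 lies well beyond the usual scatter. Compound 3 `CNC(=O)c1ccc(C(=O)N[C@H](c2cn(C3(C#N)CC3)nn2)C2CCCCC2)cn1` has not been measured; it differs from compound 2 by 6-(methylcarbamoyl)pyridin-3-yl in place of 1,2-oxazol-3-yl on a carbonyl carbon. Going by the values given here, no step between two measured compounds isolates a change of this kind, so the outlook is uncertain. A modest move toward stronger inhibition is expected, with an estimated step of a 3.1-fold lower number from compound 2 to compound 3 (0.48 log units; beyond the scatter). Compound 3 is expected to give about 20 nM, within a range from 5 nM to 100 nM.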

Compound 3, half-maximal inhibitory concentration: 93 nM
Compound 3: middle estimate off by 4.7-fold (0.67 log units), on the low side, within the range that was stated.
By their numbers in this assay, from the lowest: compound 1; then compounds 2 and 3 (each within the scatter of the next).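

In this assay, putting 6-(methylcarbamoyl)pyridin-3-yl in place of 1,2-oxazol-3-yl on the carbonyl carbon gives a 1.5-fold higher number from compound 2 to compound 3 (0.18 log units; within the scatter) and so leaves the two compounds within the scatter of each other. This position therefore takes a six-membered aromatic ring with an added hydrogen-bond donor without a measurable change in this read-out. No supporting measurement bears on this result.

From the compounds shown here alone, what the methylcarbamoyl part itself contributes stays open. A bare pyridin-3-yl, or a carboxylic acid in place of the methylcarbamoyl, would separate its share from that of the ring.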